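The compounds below may be only part of what the source reports. "The series", "measured", "known", "first", "only" and "open" are said of these compounds alone.

Working notes on the series in a functional assay on MCF7 cells (Homo sapiens) for inhibition, read by MTT assay, with a stated time of 72 h; on this read-out higher numbers stand for weaker inhibition and lower numbers for stronger inhibition.

Three compounds share a core and a benzylsulfanyl arm. Compound 1 `Cc1cc(Nc2ccn(Cc3ccccc3)n2)n2nc(SCc3ccc(Br)cc3)nc2n1` gives 15800 nM in this assay. Compound 2 `CCCCCc1c(C)nc2nc(SCc3ccc(Cl)cc3)nn2c1Nc1cc(-c2ccccc2)[nH]n1` gives 6390 nM. Compound 3 `Cc1cc(Nc2cc(-c3ccccc3)[nH]n2)n2nc(SCc3ccc(Cl)cc3)nc2n1` gives 8260 nM. On these three numbers compound 3 stands second highest; its nearest neighbour is compound 2 and its furthest is compound 1, and both of those gaps are within the scatter, so no order among the three can be read.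

For the measured compounds named here, the only single-place step in the set is a 1.3-fold higher number from compound 2 to compound 3 (0.11 log units; within the scatter), which changes a substituent on the core, not the arm on the sulfur.

Compound 4 `Cc1cc(Nc2cc(-c3ccccc3)[nH]n2)n2nc(SCc3csc4ccccc34)nc2n1` is not yet measured. It differs from compound 3 in one place: 1-benzothiophen-3-yl in place of 4-chlorophenyl on a saturated chain carbon bound to a sulfur. Going by the values given here, no measured step touches this arm; compounds 1 and 3 differ there as well as elsewhere, and their values are within the scatter of each other, so they give no direction either. Without a step to lean on, the expectation is no change beyond the scatter, so the estimated step of a 1.0-fold lower number from compound 3 to compound 4 (0.01 log units; within the scatter) is close to flat. Compound 4 is therefore expected to give about 8000 nM in this assay, in a range from 2500 nM to 25000 nM.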

Compound 4, half-maximal inhibitory concentration: 3470 nM
Estimate against measurement, compound 4: 2.3-fold (0.36 log units) above; low and high end bracket the measured number.
By their numbers in this assay, from the lowest: compounds 4, 2, 3 and 1 (each within the scatter of the next, the first and the last beyond it).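

For the compounds shown here, on the saturated chain carbon bound to a sulfur, the step of a 2.4-fold lower number from compound 3 to compound 4 (0.38 log units; beyond the scatter) in this assay is the first single-place change on this arm and the first single-place step to lie beyond the scatter, though it is modest. Going by these compounds alone, the only earlier single-place step, a 1.3-fold higher number from compound 2 to compound 3 (0.11 log units; within the scatter), changes a substituent on the core and stays within the scatter, so this arm is the one place so far where a single change moves the read-out, here with 1-benzothiophen-3-yl, which has one five-membered aromatic ring with 1 hetero atom and one six-membered aromatic ring of carbon only, in place of 4-chlorophenyl. No measurement on hand bears on what lies behind this step.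

From the compounds shown here alone, whether the step follows the ring sulfur or the second ring stays open, and a naphthalen-1-yl or an unsubstituted phenyl on the same carbon would separate the two. Going by these compounds, the step also rests on a single pair, so whether it carries over to a core bearing pentyl, as in compound 2, remains unknown.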